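Swapping the carbamoyl of compound 1 for a thioether arm

The source may report more compounds than this note shows. Statements on the series, on what has been measured and on what is new or still open speak of the compounds shown alone.

Compound 1 `Cc1nc2c(OCc3ccccc3)cccn2c1C(N)=O` has the lowest number of the three measured compounds. In a functional assay on the whole organism with Rattus norvegicus as the target, with a stated time of 4 h, at a dose of 40 mg/kg by the intraperitoneal route (on this read-out higher numbers stand for more inhibition at the one dose given (going by the name of the read-out) and lower numbers for less inhibition), compound 1 gives 42%, the lowest of the three numbers. Compound 2 `CC(=O)c1c(C)nc2c(OCc3ccccc3)cccn12` gives 57% in this assay, and compound 3 `Cc1nc2c(OCc3ccccc3)cccn2c1CO` gives 99%.

The two changes made so far both move away from compound 1. Replacing amino with methyl on a carbonyl carbon gives a number 15 percentage points higher from compound 1 to compound 2 (beyond the scatter), a modest rise. Replacing the whole carbamoyl with hydroxymethyl on an aromatic carbon gives a number 57 percentage points higher from compound 1 to compound 3 (beyond the scatter), a large rise, and the related exchange of acetyl for hydroxymethyl gives a number 42 percentage points higher from compound 2 to compound 3 (beyond the scatter).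

Compound 4 `CSCc1c(C)nc2c(OCc3ccccc3)cccn12` carries a different group on the same aromatic carbon of the shared core: (methylsulfanyl)methyl in place of carbamoyl on an aromatic carbon. The step from compound 1 to compound 3 bears most directly on this, since both remove the carbamoyl, and the step from compound 1 to compound 2 shows that even a smaller change at that group raises the number. For the measured compounds named here, a rise is therefore expected in this assay, though compound 4 lacks the hydroxyl of compound 3, so a smaller rise than the one to compound 3 is estimated. The expected step is a number 23 percentage points higher from compound 1 to compound 4 (beyond the scatter). Compound 4 is estimated to give 65%, with a range from 40% to 90%.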

Compound 4, a percentage reported as inhibition, in the whole organism at one dose (the size of the read-out at that dose, not a potency): 29%
Estimate against measurement, compound 4: 36 percentage points above; the measured number lies below the stated range.
By their numbers in this assay, from the lowest: compound 4; then compound 1; then compound 2; then compound 3.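

In this assay, losing the carbamoyl does not by itself raise the number: (methylsulfanyl)methyl in place of carbamoyl gives a number 13 percentage points lower from compound 1 to compound 4 (beyond the scatter) and so shows that a change at this aromatic carbon can also lower the read-out, which neither compound 2 nor compound 3 had shown. The exchange of acetyl for the same group gives a number 28 percentage points lower from compound 2 to compound 4 (beyond the scatter) and the exchange of hydroxy for methylsulfanyl on the saturated chain carbon gives a number 70 percentage points lower from compound 3 to compound 4 (beyond the scatter) and this last step, the largest of the three, ties the high number of compound 3 to its hydroxy rather than to the one-carbon arm that compound 3 and compound 4 share. Nothing measured here says what lies behind these steps.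

Open, going by these compounds, is whether methoxymethyl, which keeps the oxygen of compound 3 but not its hydroxy hydrogen, would stay near compound 3 or fall toward compound 4. The same question stands for an aminomethyl group, a carboxylic acid or a longer hydroxyethyl chain on this aromatic carbon.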